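Compound 3 and a side-group swap

A few compounds are considered here, and "the series" means these few. Any claim that something is new, unique, unknown or untested is made for them only; others in the source may bear on it.

In a functional assay on KBVIN cells (Homo sapiens) for antiproliferative activity, read by sulforhodamine B assay, with a stated time of 3 days (a lower number here means a stronger inhibitor of growth, a higher number a weaker inhibitor of growth), compound 1 (`COc1ccc(NC(=O)c2cccc(Nc3ncc(F)c(Nc4ccc(F)cc4)n3)c2)cc1`) gives 15700 nM and compound 2 (`CN1CCC(C(=O)Nc2cccc(Nc3ncc(F)c(Nc4ccc(F)cc4)n3)c2)CC1`) gives 11900 nM while compound 3 (`O=C(Nc1cccc(Nc2ncc(F)c(Nc3ccc(F)cc3)n2)c1)c1ccncc1`) gives 4570 nM as the lowest number of the three. Compound 4 (`Cn1ccnc1NC(=O)c1cccc(Nc2ncc(F)c(Nc3ccc(F)cc3)n2)c1`) differs from compound 3 at one place ((1-methyl-1H-imidazol-2-yl)carbamoyl in place of ((pyridin-4-yl)carbonyl)amino on an aromatic carbon): (1-methyl-1H-imidazol-2-yl)carbamoyl in place of ((pyridin-4-yl)carbonyl)amino on an aromatic carbon.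

Among the compounds with values here, two measured steps bear on this swap, and both are modest. The first (a 3.4-fold lower number from compound 1 to compound 3 (0.54 log units; beyond the scatter)) matters most, since it also leaves a carbamoyl group behind to reach the ((pyridin-4-yl)carbonyl)amino group. Compound 4 runs this change the other way, keeping a carbamoyl group as compound 1 does at 15700 nM with a different ring on it. The second (a 2.6-fold lower number from compound 2 to compound 3 (0.42 log units; beyond the scatter)) shows that exchanging the ring alone can also move the number. Within the data shown here, compound 3 holds the lowest value so far, so a modest move to a higher number is expected. The estimated change is a 2.0-fold higher number from compound 3 to compound 4 (0.29 log units; within the scatter) in this assay with wide uncertainty. The estimate for compound 4 is 9000 nM (expected range 3500 nM to 20000 nM).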

Compound 4, concentration for 50% growth inhibition: 13100 nM
For compound 4 the middle estimate is 1.5-fold (0.16 log units) below the measured one; measured number inside the range.
By their numbers in this assay, from the lowest: compound 3; then compounds 2, 4 and 1 (each within the scatter of the next).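

At this place on the aromatic carbon, the swap in this assay gives a 2.9-fold higher number from compound 3 to compound 4 (0.46 log units; beyond the scatter) and does two things at once: it turns the amide link around and changes the ring. With the carbamoyl link kept, 1-methyl-1H-imidazol-2-yl in place of 4-methoxyphenyl gives a 1.2-fold lower number from compound 1 to compound 4 (0.08 log units; within the scatter) so these two rings read alike on that link. The step to the group carrying 1-methylpiperidin-4-yl gives a 1.1-fold higher number from compound 2 to compound 4 (0.04 log units; within the scatter) which leaves the ((pyridin-4-yl)carbonyl)amino group of compound 3 as the one group shown that stands apart.

The compounds shown leave open whether pyridin-4-yl would keep this number on a carbamoyl link, and how a carboxylic acid or a simple amine would read at this place. Nothing measured here gives a cause for any of these steps.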